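Methoxy in place of hydrogen: a small step, one limit

The source may hold more compounds than are shown below. What is called first, only, known or untested is meant among the compounds shown, and "the series" means these compounds.

Values in a functional assay on NCI-H1299 cells (Homo sapiens) for antiproliferative activity, read by MTT assay, with a stated time of 24 h (on this read-out higher numbers stand for weaker inhibition and lower numbers for stronger inhibition), for the measured compounds:
compound 1 `O=C(/C=C/c1ccc(O)cc1)NNC(=O)c1ccccc1`: 7360 nM
compound 2 `COc1ccc(C(=O)NNC(=O)/C=C/c2ccc(O)cc2)cc1`: 6640 nM
compound 3 `COc1cc(/C=C/C(=O)NNC(=O)c2ccccc2)cc(OC)c1O`: > 10000 nM, a limit of the assay and not a number

Compound 1 and compound 2 share a core and differ only by methoxy in place of hydrogen on an aromatic carbon. In this assay this gives a 1.1-fold lower number from compound 1 to compound 2 (0.04 log units; within the scatter); the two values are indistinguishable within the scatter.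

Compound 3 reaches only a limit in this assay; the assay reports the limit of > 10000 nM in this assay, at which 1 of the 3 values shown sits, for it. The difference between the core of compound 3 and the core of compound 1 is not broken down here.

Compound 4 `COc1ccc(C(=O)NNC(=O)/C=C/c2cc(OC)c(O)c(OC)c2)cc1` is not yet measured. It differs from compound 3 by methoxy in place of hydrogen on an aromatic carbon. The place is the same, word for word, as for the change from compound 1 to compound 2, so this is the same change made on the core of compound 3.

Among the measured compounds shown here, since the only measured instance of this change, a 1.1-fold lower number from compound 1 to compound 2 (0.04 log units; within the scatter), lies within the scatter, the step that the limit leaves unreadable from compound 3 to compound 4 is expected to be small as well. Compound 3 sits at a limit, so compound 4 is expected most likely to sit at or near that limit too. For compound 4 the estimate in this assay is 12000 nM. For compound 4 the range expected is from 6000 nM to 30000 nM.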

Compound 4, half-maximal inhibitory concentration: 7450 nM
Estimate against measurement, compound 4: 1.6-fold (0.21 log units) above; the measured number falls inside the stated range.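

In this assay, the change of phenyl to 4-methoxyphenyl can now be read on two cores, and on the core of compound 3 it gives an at least 1.3-fold lower number from compound 3 to compound 4 (0.12 log units; that floor lies within the scatter). Set side by side, the two instances give no sign that the change loses inhibition when carried to the second core, but they neither fix the size of the step there nor show that the change acts alike on both cores: the same change on two cores in this assay, a 1.1-fold lower number (0.04 log units; within the scatter) from compound 1 to compound 2 and an at least 1.3-fold lower number (0.12 log units; that floor lies within the scatter) from compound 3 to compound 4; the limit leaves it open whether they differ. Compound 3 carries a limit of the assay and not a number, so the printed step is only a floor and the true step may be larger: the limit of > 10000 nM in this assay, at which 1 of the 4 values shown sits.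

The compounds shown leave open whether an amine, a carboxylic acid or a longer chain such as ethoxy, placed where the methoxy enters, would give a step of a different size in this assay. Among the compounds shown here, also open is how far the change carries beyond these two cores, since the only step read as a full number is the one between compound 1 and compound 2, and no core with a different group on its other ring is available to test it.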